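The source may hold more compounds than are shown below. What is called first, only, known or untested is meant among the compounds shown, and "the series" means these compounds.

Measured in an ADME assay on microsomes from liver (Homo sapiens) for metabolic stability, read by LC-MS, using NADPH, with a stated time of 10 min, tested at 10 uM; a higher number here means that the compound lasts longer, a lower number that the compound disappears faster:

compound 1 `CC(C)(C)n1nc(Oc2cc(O)ccn2)c2c(N)ncnc21` gives 1.4 h
compound 2 `N#Cc1ccnc(Oc2nn(C3CCC3)c3ncnc(N)c23)c1` gives 2.35 h
compound 3 `CO[C@H]1CC[C@H](n2nc(Oc3cc(C(F)(F)F)ccn3)c3c(N)ncnc32)CC1` gives > 2.41 h

The value of compound 3 is a limit of this assay, not a number, so compound 3 is known only to sit at the limit of > 2.41 h in this assay, at which 1 of the 3 values shown sits, at the upper edge of what was seen. Compound 4 `Nc1ncnc2c1c(Oc1cc(C(F)(F)F)ccn1)nn2[C@@H]1CC[C@H](N)C1` has not yet been measured in this assay. It differs from compound 3 in one place: 3-aminocyclopentyl in place of 4-methoxycyclohexyl on an aromatic nitrogen. Within the data shown here, no pair of measured compounds shows this change, so no measured step tells its size. For compound 4 the step of an at least 1.3-fold lower number from compound 3 to compound 4 (0.12 log units; that floor lies within the scatter) is expected to be small, downward, and within the usual scatter. The half-life of compound 4 in this assay is estimated at 1.8 h, between 0.8 h and 3 h.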

Compound 4, half-life: > 2.41 h
Compound 4 ended at the assay's limit; the forecaster's own chance of this, stated with the estimate: 25%; at least 1.3-fold (0.12 log units) between middle value and limit.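

Among these compounds, compound 3 and compound 4 both end at a limit, not a number, in this assay, so no step between them can be read: the limit of > 2.41 h in this assay, at which 2 of the 4 values shown sit. As far as these compounds go, whether the half-lives of compound 3 and compound 4 differ stays open.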